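Diethylamino in place of pyrrolidinyl on the propoxy chain

The source may hold more compounds than are shown below. What is called first, only, known or untested is meant among the compounds shown, and "the series" means these compounds.

Three compounds of the series have been run in a functional assay on DLD-1 cells (Homo sapiens) for cytotoxicity, read by WST assay, with a stated time of 72 h; on this read-out lower numbers stand for stronger inhibition and higher numbers for weaker inhibition. Compound 1 `CCN(CC)CCCOc1cc2ncnc(Nc3nc4ccc(C(=O)Nc5c(C)cccc5C)cc4s3)c2cc1OC` reaches only the limit of the assay; its value in this assay, > 100000 nM, is a limit and not a number (the limit of > 100000 nM in this assay, at which 1 of the 3 values shown sits). Compound 2 `COc1cc2c(Nc3nc4ccc(C(=O)Nc5c(C)cc(C)cc5C)cc4s3)ncnc2cc1OCCCN1CCCCC1` gives 24500 nM in this assay. Among the compounds with values here, compound 3 `COc1cc2c(Nc3nc4ccc(C(=O)Nc5c(C)cc(C)cc5C)cc4s3)ncnc2cc1OCCCN1CCCC1` gives 5900 nM in this assay, the lowest of the two numbers measured; the only step known is a 4.2-fold lower number from compound 2 to compound 3 (0.62 log units; beyond the scatter).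

Compound 4 `CCN(CC)CCCOc1cc2ncnc(Nc3nc4ccc(C(=O)Nc5c(C)cc(C)cc5C)cc4s3)c2cc1OC` has not yet been measured in this assay. It differs from compound 3 in one place: diethylamino in place of pyrrolidin-1-yl on a saturated chain carbon, three bonds along the chain from an oxygen on an aromatic ring. Within the data shown here, no measured step covers this change. Among the measured compounds shown here, the one measured step, from a six-membered to a five-membered saturated amine ring, went downward, but the change here opens the ring rather than shrinking it, so that step gives no direct guide. For the measured compounds named here, compound 1, which also carries the diethylamino group but lacks the fourth methyl on the anilide ring, sits at the limit; compound 3 and compound 4 differ from compound 1 in two places, so no step between them can be read.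

For compound 4 the number in this assay is expected to come out higher than for compound 3, by a step of a 2.5-fold higher number from compound 3 to compound 4 (0.41 log units; beyond the scatter), with wide uncertainty. The estimate for compound 4 is 15000 nM, in a range from 4000 nM to 60000 nM.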

Compound 4, half-maximal inhibitory concentration: 6800 nM
Compound 4: middle estimate off by 2.2-fold (0.34 log units), on the high side; low and high end bracket the measured number.
By their numbers in this assay, from the lowest: compounds 3 and 4 (each within the scatter of the next); then compound 2. At a limit, above all of these: compound 1.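

In this assay, opening the five-membered ring to diethylamino on the propoxy chain leaves the read-out unresolved, at a 1.2-fold higher number from compound 3 to compound 4 (0.06 log units; within the scatter), so a ring at this place is not needed to hold the value among the compounds shown. The diethylamino group also joins pyrrolidin-1-yl in standing apart from piperidin-1-yl, at a 3.6-fold lower number from compound 2 to compound 4 (0.56 log units; beyond the scatter), alongside the earlier 4.2-fold lower number from compound 2 to compound 3 (0.62 log units; beyond the scatter), which leaves the six-membered ring as the one amine of the three with the higher number. With the diethylamino group held constant, methyl in place of hydrogen on an aromatic carbon gives an at least 14-fold lower number from compound 1 to compound 4 (1.16 log units; beyond the scatter), and since compound 1 carries a limit and not a number, this step gives only a bound on the size of the change: the limit of > 100000 nM in this assay, at which 1 of the 4 values shown sits.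

Whether that methyl matters equally with a pyrrolidin-1-yl or piperidin-1-yl group on the chain stays open, as compound 1 is the only member shown without it. Also open, going by these compounds, are other amines at the end of the same propyl chain, such as morpholine, N-methylpiperazine or dimethylamino, and a shorter ethyl or longer butyl chain carrying diethylamino.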